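Amide Cap Change on a Cyclopropane Carboxamide Series

The source may report more compounds than this note shows. Statements on the series, on what has been measured and on what is new or still open speak of the compounds shown alone.

Measured so far:
- Compound 1, `CCC(=O)N[C@@H](C)c1ccc(NC(=O)NCc2cccnc2)cc1`: 1330 nM
- Compound 2, `CCC(=O)N[C@@H](C)c1ccc(NC(=O)[C@H]2C[C@@H]2c2cccnc2)cc1`: 22 nM

Both compounds were tested in a functional assay on COR-L23 cells (Homo sapiens) for antiproliferative activity, read by CellTiter-Glo, with a stated time of 4 days; a lower number here means a stronger inhibitor, a higher number a weaker inhibitor. Compound 2 stands at the lowest of the two numbers; its nearest neighbour, compound 1, sits at a higher number, a gap well beyond the scatter of repeated tests. Compound 3, `C[C@H](NC(=O)c1ccccn1)c1ccc(NC(=O)[C@H]2C[C@@H]2c2cccnc2)cc1`, keeps the whole of compound 2 except for the group on the carbonyl carbon next to the amide-type nitrogen, where the change is pyridin-2-yl in place of ethyl on a carbonyl carbon. Going by the values given here, no measured pair here shows what swapping an ethyl for a pyridin-2-yl at that carbonyl does, so the size and direction of the step are unknown. The expectation is that the step from compound 2 to compound 3 will be small and may fall within the scatter, a 1.4-fold higher number from compound 2 to compound 3 (0.13 log units; within the scatter). Compound 3 is expected to give about 30 nM, within a range from 8 nM to 110 nM.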

Compound 3, half-maximal inhibitory concentration: 46 nM
The estimate for compound 3 lay 1.5-fold (0.19 log units) below the measured number; low and high end bracket the measured number.
By their numbers in this assay, from the lowest: compound 2; then compound 3; then compound 1.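

In this assay, the position on the carbonyl carbon accepts an aromatic ring as well as a short chain: pyridin-2-yl in place of ethyl gives a 2.1-fold higher number from compound 2 to compound 3 (0.32 log units; beyond the scatter), a modest loss. Compound 3 still reaches 46 nM, so this carbonyl can carry a much bulkier group without the activity collapsing. This one swap therefore shows that the ethyl is not essential for activity in these cells, and that the ring costs only a small part of it.

The compounds shown leave open whether the loss follows from the ring itself or from its nitrogen, a question that phenyl or pyridin-3-yl at the same carbonyl would address, and whether a longer chain such as butyl or an added amine would be better or worse. No measurement here explains the size of this step.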